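The source may report more compounds than this note shows. Statements on the series, on what has been measured and on what is new or still open speak of the compounds shown alone.

Working notes on the series, read in an ADME assay on MRC5 cells (Homo sapiens) for cytotoxicity, read by MTT assay, with a stated time of 72 h; a higher number here means a weaker inhibitor, a lower number a stronger inhibitor. Compound 1 (`CC(C)(C)C1=CC(=O)C=C(NCC(=O)O)C1=O`) gives > 200000 nM, and this is a limit of this assay, not a number. Among the compounds with values here, compound 2 (`CC1=CCC[C@H]2[C@](C)(CC3=CC(=O)C(N4CCC[C@H]4C(=O)O)=CC3=O)[C@@H](C)CC[C@]12C`) gives 96000 nM, the only actual number so far, so it can be placed on no scale of measured neighbours. Compound 3 (`CC1=CCC[C@H]2[C@](C)(CC3=CC(=O)C=CC3=O)[C@@H](C)CC[C@]12C`) is the next to be read. The change from compound 2 is hydrogen in place of 2-carboxypyrrolidin-1-yl on a double-bonded ring carbon, three ring bonds from the ring atom that bears a large group. Within the data shown here, no measured pair differs in one place only, so no step in hand sizes this change, and the expectation below is a judgement with a wide range. Compound 2, at 96000 nM, reads as a weak inhibitor, which leaves room for movement towards lower numbers. The expected size and direction, towards stronger inhibition and beyond the usual scatter, is a 4.8-fold lower number from compound 2 to compound 3 (0.68 log units; beyond the scatter). For compound 3 the estimated value is 20000 nM, with an expected range of 5000 nM to 70000 nM.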

Compound 3, half-maximal inhibitory concentration: > 200000 nM
Compound 3 gave a limit, no number; the forecaster's own chance of this, stated with the estimate: 5%; middle value at least 10-fold (1.00 log units) away from the limit.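

In this assay, this position now has its first measured step, an at least 2.0-fold higher number from compound 2 to compound 3 (0.31 log units; beyond the scatter), and it runs towards weaker inhibition. On the double-bonded ring carbon, three ring bonds from the ring atom that bears a large group, the 2-carboxypyrrolidin-1-yl compound therefore reads as the stronger of the pair, and hydrogen at that carbon does not bring a stronger reading in this assay. Compound 3 gives > 200000 nM, which is a limit and not a number, so this single pair fixes the direction of the change but not its full size.

Still open, as far as these compounds go, is whether a plain pyrrolidin-1-yl group, a methyl ester of the carboxylic acid or a simple open-chain amine at this carbon would read like compound 2 or like compound 3, so the step cannot yet be assigned to the carboxylic acid, the ring or the nitrogen. How far compound 3 lies from compound 2 also stays open, and the step gives only a lower bound on its size: the limit of > 200000 nM in this assay, at which 2 of the 3 values shown sit.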